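Benzyl in Place of Isopropyl: Expected Cytotoxicity of Compound 3

A few compounds are considered here, and "the series" means these few. Any claim that something is new, unique, unknown or untested is made for them only; others in the source may bear on it.

Compound 1, `Cc1ccc(S(=O)(=O)/N=C(/CCNC2=CC(=O)c3ccccc3C2=O)Nc2ccc(Cl)cc2Cl)cc1`, gives 32900 nM in a functional assay on A549 cells (Homo sapiens) for cytotoxicity, read by MTT assay, with a stated time of 48 h; a higher number here means a weaker inhibitor, a lower number a stronger inhibitor.
Compound 2, `Cc1ccc(S(=O)(=O)/N=C(/CCNC2=CC(=O)c3ccccc3C2=O)NC(C)C)cc1`, gives 44300 nM in this assay.

Going by the values given here, compound 2 holds the higher of the two numbers measured so far, yet the gap to compound 1 lies within the usual scatter: a 1.3-fold higher number from compound 1 to compound 2 (0.13 log units; within the scatter). Compound 3, `Cc1ccc(S(=O)(=O)/N=C(/CCNC2=CC(=O)c3ccccc3C2=O)NCc2ccccc2)cc1`, differs from compound 2 by benzyl in place of isopropyl on an amine nitrogen. Among the compounds with values here, only one measured step bears on this position on the amine nitrogen, and that step, a 1.3-fold higher number from compound 1 to compound 2 (0.13 log units; within the scatter), exchanged an aromatic group for a small alkyl group without moving the number beyond the scatter. Compound 3 now brings a six-membered aromatic ring back onto the same nitrogen, one carbon further out. Within the data shown here, with no other steps available, the expected change a 1.1-fold lower number from compound 2 to compound 3 (0.04 log units; within the scatter) is none beyond the scatter, in either direction. For compound 3 the estimated value in this assay is 40000 nM, with a range from 18000 nM to 90000 nM.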

Compound 3, half-maximal inhibitory concentration: 7410 nM
The estimate for compound 3 lay 5.4-fold (0.73 log units) above the measured number; the measured number lies below the stated range.
By their numbers in this assay, from the lowest: compound 3; then compounds 1 and 2 (each within the scatter of the next).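

This position is not indifferent to what sits on the amine nitrogen: in this assay, benzyl in place of isopropyl gives a 6.0-fold lower number from compound 2 to compound 3 (0.78 log units; beyond the scatter), a change beyond the scatter, which the earlier step did not show. Benzyl also differs from 2,4-dichlorophenyl, with a 4.4-fold lower number from compound 1 to compound 3 (0.65 log units; beyond the scatter), so an aromatic ring on this nitrogen is not enough by itself: compound 1 carries one and still stays within the scatter of compound 2. No measurement shown here explains why benzyl gives the lowest number of the three.

Benzyl and 2,4-dichlorophenyl differ both in the extra carbon and in the chlorines, so the two contributions cannot yet be separated. A plain phenyl group, a dichlorobenzyl group or a longer 2-phenylethyl chain on the same nitrogen would address this.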